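The compounds below may be only part of what the source reports. "The series", "measured", "known", "first", "only" and "open" are said of these compounds alone.

Measured so far:
compound 1 `Brc1ccccc1OCC1=NCCO1`: 62.8%
compound 2 `O=[N+]([O-])c1ccc(OCC2=NCCO2)cc1`: 77.1%

In a functional assay on the whole organism for inhibition, with Rattus norvegicus as the target, read by paw edema, with a stated time of 30 min, at a dose of 80 mg/kg by the oral route (a lower number here means a weaker effect, a higher number a stronger effect of the compound at the dose given), compound 1 gives 62.8%, the lower of the two numbers. Compound 2 gives 77.1%, a difference beyond the usual scatter. Compound 3 `Fc1ccccc1OCC1=NCCO1` has not yet been measured. It differs from compound 1 by fluoro in place of bromo on an aromatic carbon. For the measured compounds named here, no measured pair shows what such a change does here, so the expectation rests on compound 1 alone. The step of a number 4.8 percentage points lower from compound 1 to compound 3 (within the scatter) is expected to be small and slightly downward, within the scatter. Compound 3 is estimated at 58%, with a range from 40% to 75%.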

Compound 3, a percentage reported as inhibition, in the whole organism at one dose (the size of the read-out at that dose, not a potency): 60.1%
Compound 3: middle estimate off by 2.1 percentage points, on the low side; the range from low to high includes it.
By their numbers in this assay, from the lowest: compounds 3 and 1 (each within the scatter of the next); then compound 2.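

In this assay, fluoro in place of bromo on an aromatic carbon, ortho to a group of 7 heavy atoms, gives a number 2.7 percentage points lower from compound 1 to compound 3 (within the scatter). For the compounds shown here, this is the first direct view of a change at this position, and the two halogens cannot be told apart here at this dose. Nothing available explains this result. Going by these compounds, whether an amine, a methoxy group or a carboxylic acid at the same position would give a different number remains open. So does whether the same exchange would matter elsewhere on the aromatic ring.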